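The source may report more compounds than this note shows. Statements on the series, on what has been measured and on what is new or still open speak of the compounds shown alone.

The measured compounds:
compound 1 `COc1cc(-c2cc(/C=C/C(=O)c3ccc(N)cc3)[nH]n2)cc(OC)c1OC`: 76%
compound 2 `COc1ccc(-c2cc(/C=C/C(=O)c3ccc(OC)c(OC)c3)[nH]n2)cc1`: 71%
compound 3 `COc1cc(-c2cc(/C=C/C(=O)c3ccc(Cl)c(Cl)c3)[nH]n2)cc(OC)c1OC`: 87%

Three compounds built on one shared core were tested in a functional assay on PC-3 cells (Homo sapiens) for cytotoxicity, read by sulforhodamine B assay, with a stated time of 48 h, tested at 1 uM; on this read-out higher numbers stand for a weaker effect at the one concentration tested and lower numbers for a stronger effect. In this assay compound 1 gives 76%, the second highest of the three numbers. Its nearest neighbour is compound 2, whose 71% lies within the scatter of compound 1. Compound 3, with 87%, lies furthest away, and the step of a number 11 percentage points higher from compound 1 to compound 3 (beyond the scatter) is beyond the scatter; that step exchanges the group on the carbonyl carbon.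

Compound 4 `COc1ccc(-c2cc(/C=C/C(=O)c3ccc(N)cc3)[nH]n2)cc1OC` has not been measured. It differs from compound 1 in one place: hydrogen in place of methoxy on an aromatic carbon. For the measured compounds named here, this change sits on the six-membered aromatic ring that bears the methoxy groups, not on the carbonyl carbon, so none of the measured steps bears directly on it; the only step beyond the scatter alters a different part of the molecule. Compound 2 also carries fewer methoxy groups, but it differs from compound 1 on both rings at once, so the two values say little about this single change. With nothing pointing in either direction, no step beyond the scatter is expected in this assay. Compound 4 is therefore estimated at 76%, between 60% and 92%, which means an expected step of no change at the digits printed from compound 1 to compound 4 (within the scatter).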

Compound 4, a percentage reported as activity, at one concentration (the size of the read-out at that concentration, not a potency): 89%
Compound 4: middle estimate off by 13 percentage points, on the low side; low and high end bracket the measured number.
By their numbers in this assay, from the lowest: compounds 2 and 1 (each within the scatter of the next); then compounds 3 and 4 (each within the scatter of the next).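

Removing this one methoxy group, ortho to a methoxy group and meta to a large group, is not a neutral edit: in this assay, hydrogen in its place gives a number 13 percentage points higher from compound 1 to compound 4 (beyond the scatter), and a higher number here means a weaker effect at the one concentration tested. Until now, the only single change with a step beyond the scatter sat on the carbonyl carbon, as a number 11 percentage points higher from compound 1 to compound 3 (beyond the scatter); this result shows that the ring bearing the methoxy groups also affects the read-out, and both single changes shown for compound 1 raise the number. Nothing at hand explains why this methoxy group counts, so the step remains an observation without a known cause.

The compounds shown do not reveal whether methoxy itself is needed on this carbon, and a hydroxy group, an ethoxy group or a chlorine atom there would help to settle that. Going by these compounds, it also remains open whether hydrogen in place of methoxy would give a similar step with 3,4-dichlorophenyl on the carbonyl carbon, or at other concentrations.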